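The compounds below may be only part of what the source reports. "The series", "measured", "known", "first", "only" and "open" are said of these compounds alone.

Values in a functional assay on MCF-A cells (Homo sapiens) for cytotoxicity; a higher number here means a weaker inhibitor of growth, a lower number a stronger inhibitor of growth:
- compound 1 `COc1ccc(C2=C(c3ccc(SC)cc3)CC3CCCN3C2=O)cc1OC(=O)CNC(=O)OC(C)(C)C`: 6000 nM
- compound 2 `CSc1ccc(C2=C(c3ccc(C)c(C)c3)C(=O)N3CCCC3C2)cc1`: 800 nM
- compound 3 `CSc1ccc(C2=C(c3ccc(O)c(O)c3)C(=O)N3CCCC3C2)cc1`: 80000 nM

Compound 3 has the highest number of the three, which makes it the weakest growth inhibitor so far in this assay. Compound 1 lies nearest to it, and compound 2 lies furthest.

The next compound is compound 4 `CSc1ccc(C2=C(c3ccc(F)cc3)C(=O)N3CCCC3C2)cc1`, with 4-fluorophenyl in place of 3,4-dihydroxyphenyl on a double-bonded ring carbon.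

Within the data shown here, only one measured step bears on this change. It sits at the same ring carbon, with 3,4-dihydroxyphenyl in place of 3,4-dimethylphenyl, and it is large: a 100-fold higher number from compound 2 to compound 3 (2.00 log units; beyond the scatter). Among the measured compounds shown here, compound 1 is linked to the others by no single-place step, so it adds no step here. For the measured compounds named here, no measured compound carries 4-fluorophenyl, and the size of the step therefore rests on this one comparison.

Compound 4 also leaves the 3,4-dihydroxyphenyl group behind, so a large move back towards the number of compound 2 is expected, though perhaps not all the way. The expected step is a 53-fold lower number from compound 3 to compound 4 (1.73 log units; beyond the scatter), large and towards a lower number. For compound 4 the estimated value is 1500 nM, with an expected range of 400 nM to 6000 nM.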

Compound 4, concentration for 50% growth inhibition: 800 nM
Compound 4: the middle estimate sits 1.9-fold (0.27 log units) above what was measured; measured number inside the range.
By their numbers in this assay, from the lowest: compounds 2 and 4 (each within the scatter of the next); then compound 1; then compound 3.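

In this assay, 4-fluorophenyl in place of 3,4-dihydroxyphenyl on the double-bonded ring carbon gives a 100-fold lower number from compound 3 to compound 4 (2.00 log units; beyond the scatter) and so shows that the high number of compound 3 is not shared by a second replacement at this carbon. Among these compounds, the comparison of 4-fluorophenyl with 3,4-dimethylphenyl gives no change at the digits printed from compound 2 to compound 4 (within the scatter) and places these two groups together, while 3,4-dihydroxyphenyl, the only one of the three groups with hydrogen-bond donors, stands apart from both, although three groups are too few to tie the difference to those donors. No measurement in this set gives a reason for the separation of 3,4-dihydroxyphenyl from the other two groups.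

The compounds shown leave open whether a phenyl ring carrying a single hydroxyl group would stay with compound 3 or join compound 2 and compound 4, which would indicate whether both hydroxyl groups are needed for the large step. Also open, on these data alone, is how an aminophenyl group or a carboxylic acid on the phenyl ring would read at this carbon, with the 4-(methylsulfanyl)phenyl group and the shared core held constant.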